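This account rests on a few compounds, and the source may have more. Where it says the series, first, only, none or still open, it means among the compounds named here.

Compound 1, `COc1ccc(OC)c(Sc2ccc3nnc(-c4ccccn4)n3n2)c1`, was tested in an assay on isolated protein for inhibition of Leucine-rich repeat serine/threonine-protein kinase 2 (Homo sapiens), in the presence of a further agent that is not named here (on this read-out higher numbers stand for weaker inhibition and lower numbers for stronger inhibition), where compound 1 gives 496 nM. Among the compounds with values here, its only measured companion is compound 2, `COc1ccc(OC)c(Sc2ccc3nnc(-c4ccncc4)n3n2)c1`, which in this assay gives 349 nM. Within the data shown here, the single step between them, a 1.4-fold lower number from compound 1 to compound 2 (0.15 log units; within the scatter), replaces one six-membered aromatic ring with another at the same place on the shared core, and it stays within the scatter; compound 1 thus has the higher of the two numbers, but the gap to compound 2 does not separate the two beyond what repeated measurements would show.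

Compound 3, `COc1ccc(OC)c(Sc2ccc3nnc(Cc4cnn(C)c4)n3n2)c1`, departs from compound 1 by a larger change: (1-methyl-1H-pyrazol-4-yl)methyl in place of pyridin-2-yl on an aromatic carbon. Among the measured compounds shown here, the one measured step at this place, from a six-membered ring to another six-membered ring, was small. For the measured compounds named here, no measured pair shows the effect of inserting a methylene link or of moving to a five-membered ring, so there is nothing to point to a direction. On the evidence of compound 1 and compound 2, the expected step of a 1.1-fold higher number from compound 1 to compound 3 (0.04 log units; within the scatter) is none beyond the scatter, with a wide margin for the untested change. Compound 3 is therefore estimated at 550 nM, within 150 nM to 2000 nM.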

Compound 3, half-maximal inhibitory concentration: 32000 nM
Estimate against measurement, compound 3: 58-fold (1.76 log units) below, and the stated range ends below it.
By their numbers in this assay, from the lowest: compounds 2 and 1 (each within the scatter of the next); then compound 3.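

In this assay, the place on the aromatic carbon between two ring nitrogen atoms proves far from indifferent to what it carries: (1-methyl-1H-pyrazol-4-yl)methyl in place of pyridin-2-yl gives a 65-fold higher number from compound 1 to compound 3 (1.81 log units; beyond the scatter), and the same group in place of pyridin-4-yl gives a 92-fold higher number from compound 2 to compound 3 (1.96 log units; beyond the scatter). Within the data shown here, the earlier exchange of one pyridine for the other showed only that these two groups cannot be told apart here, whereas both steps to compound 3 lie well beyond the scatter and point the same way, towards weaker inhibition. No evidence is available on why this change has so large an effect.

The step from either pyridine brings in a methylene link and a five-membered aromatic ring with 2 hetero atoms together, so the compounds shown cannot divide the effect between them; a pyridin-4-ylmethyl group or a 1-methyl-1H-pyrazol-4-yl group set directly on the core would bear on that question. Going by these compounds, how a small alkyl chain, an amine or a carboxylic acid would read at this place also stays open, as does whether the large step holds on a core with a different group in place of the shared dimethoxyphenyl thioether.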